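Phenyl to 4-methoxyphenyl in the shared core series

The source may report more compounds than this note shows. Statements on the series, on what has been measured and on what is new or still open speak of the compounds shown alone.

Measured in a functional assay on DLA cells (Mus musculus) for cytotoxicity, read by LDH release, with a stated time of 48 h; on this read-out lower numbers stand for stronger inhibition and higher numbers for weaker inhibition:
- Compound 1 `COc1ccc(-c2csc(NC(=O)COc3ccc(C(=O)c4ccccc4)cc3C)n2)cc1`: 26200 nM
- Compound 2 `Cc1ccc(C(=O)c2ccc(OCC(=O)Nc3nc(-c4ccccc4)cs3)c(C)c2)cc1`: 27100 nM

Compound 2 stands within the scatter of compound 1, so the two values cannot be separated. Compound 3 `COc1ccc(-c2csc(NC(=O)COc3ccc(C(=O)c4ccc(C)cc4)cc3C)n2)cc1` follows from compound 2 by methoxy in place of hydrogen on an aromatic carbon, para to a large group, that is, phenyl to 4-methoxyphenyl. Among the compounds with values here, no measured step isolates this change. Compound 1 also carries 4-methoxyphenyl and gives 26200 nM, so no step beyond the scatter is expected in this assay. The expected 1.1-fold lower number from compound 2 to compound 3 (0.04 log units; within the scatter) is small. For compound 3 the estimated value is 25000 nM, with an expected range of 12000 nM to 50000 nM.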

Compound 3, half-maximal inhibitory concentration: 18700 nM
Compound 3: the middle estimate sits 1.3-fold (0.13 log units) above what was measured, and the stated range covers the measured number.
By their numbers in this assay, from the lowest: compounds 3, 1 and 2 (each within the scatter of the next).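

In this assay methoxy in place of hydrogen on an aromatic carbon, para to a large group (a 1.4-fold lower number from compound 2 to compound 3 (0.16 log units; within the scatter)), and the added methyl group (a 1.4-fold lower number from compound 1 to compound 3 (0.15 log units; within the scatter)) both stay within the scatter. At these places on the shared core, neither group can therefore be told apart from hydrogen. No supporting data bear on this result.

From the compounds shown here alone, whether an amine or a carboxylic acid at the methoxy place would give a step beyond the scatter remains open, as does the outcome for a longer chain there.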